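Swapping Methylsulfanyl for a Selenium-Bearing Benzyl Group

The source may hold more compounds than are shown below. What is called first, only, known or untested is meant among the compounds shown, and "the series" means these compounds.

Three compounds share a core in which a carbon doubly bonded to nitrogen carries two amide-type nitrogens plus one further side group, and each has been tested in a functional assay on PC-3 cells (Homo sapiens) for cytotoxicity, read by MTT assay, with a stated time of 72 h; a higher number here means a weaker inhibitor of growth, a lower number a stronger inhibitor of growth. Compound 1 `CS/C(=N\C(=O)c1ccno1)NC(=O)c1ccno1` gives 99200 nM in this assay, the highest number of the three. Compound 3 `CS/C(=N\C(=O)c1ccco1)NC(=O)c1ccco1` gives 56200 nM in this assay, a number within the scatter of compound 1, so the two cannot be told apart. Compound 2 `C[Se]/C(=N\C(=O)c1sccc1Cl)NC(=O)c1sccc1Cl` gives 970 nM in this assay, a far lower number, well beyond the scatter of compound 1; it carries selenium where compounds 1 and 3 carry sulfur, but its amide arms also differ, so the gap cannot be tied to a single change.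

Compound 4 `O=C(/N=C(/NC(=O)c1ccno1)[Se]Cc1ccccc1)c1ccno1` has not yet been measured. It differs from compound 1 in one place: a group of 8 heavy atoms (7 carbon, 1 selenium; one six-membered aromatic ring of carbon only) in place of a group of 2 heavy atoms (1 carbon, 1 sulfur; no ring), on a carbon with a double bond to nitrogen.

For the measured compounds named here, no measured pair isolates this change. Going by the values given here, still, because compound 2 gives 970 nM as the only selenium-bearing compound, a shift toward a lower number is expected. The expected step is a 9.9-fold lower number from compound 1 to compound 4 (1.00 log units; beyond the scatter), a moderate move downward with wide uncertainty. Compound 4 is therefore estimated at 10000 nM, within a range from 1500 nM to 70000 nM.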

Compound 4, concentration for 50% growth inhibition: 53100 nM
Estimate against measurement, compound 4: 5.3-fold (0.73 log units) below, and the stated range covers the measured number.
By their numbers in this assay, from the lowest: compound 2; then compounds 4, 3 and 1 (each within the scatter of the next).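

In this assay, for the compounds shown here, the first pair that differs in one place gives a 1.9-fold lower number from compound 1 to compound 4 (0.27 log units; within the scatter). Exchanging methylsulfanyl for the much larger selenium-bearing benzyl group, on a carbon with a double bond to nitrogen, therefore leaves the two compounds impossible to tell apart, so this position takes on an added carbon ring and a different heavy atom with no readable shift in the number. Since the selenium and the ring arrive together in this single step, the pair speaks only for the whole exchange and not for selenium alone, and no further data bear on this result.

The compounds shown leave open whether either part of the exchange has an effect of its own that the other cancels, which a benzylsulfanyl group on the same carbon would help to separate, and whether an amine or a longer alkyl chain there would give a step beyond the scatter. They also leave open what lies behind the number of compound 2 (970 nM), whose selenium and amide arms both differ from those of compound 1.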